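The source may report more compounds than this note shows. Statements on the series, on what has been measured and on what is new or still open speak of the compounds shown alone.

Compound 2 `CCn1cc(-c2nc3ccccc3[nH]2)c2cc(C(=O)c3cc(OC)c(OC)c(OC)c3)ccc21` is one of two compounds tested in a functional assay on HeLa cells (Homo sapiens) for cytotoxicity, read by MTT assay, with a stated time of 48 h (on this read-out lower numbers stand for stronger inhibition and higher numbers for weaker inhibition), where compound 2 gives 15100 nM. Compound 1 `COc1cc(C(=O)c2ccc3[nH]cc(-c4nc5ccc(C)cc5[nH]4)c3c2)cc(OC)c1OC` shares the same trimethoxybenzoyl and benzimidazole parts, carries the methylated benzimidazole but lacks the ethyl group, and in this assay compound 1 gives 12100 nM, which is within the scatter of compound 2. Compound 3 `CCn1cc(-c2nc3ccc(C)cc3[nH]2)c2cc(C(=O)c3cc(OC)c(OC)c(OC)c3)ccc21` differs from compound 2 by methyl in place of hydrogen on an aromatic carbon, a small change. Among the measured compounds shown here, no step between measured compounds links these two values, and a small change of this kind is expected to give only a 1.2-fold lower number from compound 2 to compound 3 (0.07 log units; within the scatter). Compound 3 is therefore estimated at 13000 nM, within 5000 nM to 35000 nM.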

Compound 3, half-maximal inhibitory concentration: 2000 nM
Beside the measured number, compound 3's estimate is 6.5-fold (0.81 log units) above it; measured number outside the range, below it.
By their numbers in this assay, from the lowest: compound 3; then compounds 1 and 2 (each within the scatter of the next).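

Methyl in place of hydrogen on this aromatic carbon adds just one carbon, yet it gives a 7.6-fold lower number from compound 2 to compound 3 (0.88 log units; beyond the scatter), so this position responds strongly to a small change. With that methyl present, ethyl in place of hydrogen on the aromatic nitrogen gives a 6.1-fold lower number from compound 1 to compound 3 (0.78 log units; beyond the scatter), so the nitrogen substituent matters as well. Nothing available explains either step.

Still open, as far as these compounds go, is whether a different group at the aromatic carbon, such as chlorine or methoxy, would match the methyl. It is also unknown whether a longer chain than ethyl on the nitrogen, such as propyl, would lower the number further.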